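A Chloro Substituent Tested on Two Different Cores

The source may hold more compounds than are shown below. What is called first, only, known or untested is meant among the compounds shown, and "the series" means these compounds.

Compound 2 `CN(C)C(=O)c1cnc2ccccc2c1NCCCN1CCN(c2ccccc2OCC(F)(F)F)CC1` and compound 1 `CN(C)C(=O)c1cnc2c(Cl)cccc2c1NCCCN1CCN(c2ccccc2OCC(F)(F)F)CC1` share one core and differ by chloro in place of hydrogen on an aromatic carbon. In a functional assay on aorta for antagonist activity at Alpha-1D adrenergic receptor (Rattus norvegicus) (a higher number here means weaker binding, a lower number tighter binding), compound 2 gives 100 nM, and compound 1 gives 126 nM; the step is a 1.3-fold higher number from compound 2 to compound 1 (0.10 log units; within the scatter). Compound 3 `COc1cc(F)ccc1N1CCN(CCCNc2c(C(=O)N(C)C)c[nH]c3ccn[n+]2-3)CC1` is built on another core, and the difference between the two cores is not broken down here. In this assay compound 3 gives 100 nM, level with compound 2 at the digits shown. Compound 4 `COc1cc(F)ccc1N1CCN(CCCNc2c(C(=O)N(C)C)c[nH]c3c(Cl)cn[n+]2-3)CC1` has not yet been measured; it differs from compound 3 by chloro in place of hydrogen on an aromatic carbon. This is the same kind of change as that from compound 2 to compound 1, not the same change: there the place was a six-membered aromatic ring of carbon only, ortho to a fused ring and meta to a fused ring, here it is a five-membered aromatic ring with 2 nitrogen, two ring bonds from the ring nitrogen. For compound 4 the expected step in this assay is a 1.2-fold higher number from compound 3 to compound 4 (0.08 log units; within the scatter). Going by the values given here, that expectation rests on a 1.3-fold higher number from compound 2 to compound 1 (0.10 log units; within the scatter), the only measured instance of this kind of change. Compound 4 is therefore estimated at 120 nM, with a likely range from 55 nM to 260 nM.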

Compound 4, dissociation constant: 158 nM
For compound 4 the middle estimate is 1.3-fold (0.12 log units) below the measured one; low and high end bracket the measured number.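

In this assay chloro in place of hydrogen on an aromatic carbon brings a 1.6-fold higher number from compound 3 to compound 4 (0.20 log units; within the scatter) on the core of compound 3, so the change stays within the scatter on this core as well. Set beside the earlier step, the two results do not separate: the same change on two cores in this assay, a 1.3-fold higher number (0.10 log units; within the scatter) from compound 2 to compound 1 and a 1.6-fold higher number (0.20 log units; within the scatter) from compound 3 to compound 4, 1.3-fold (0.10 log units) apart, within the scatter of two such steps. This shows that, across these two pairs, the change carries from one core to the other without a detectable difference in its size, but it does not show that chloro has a real effect on either core, and two pairs, with the chloro on a different kind of ring in each, give no rule for the series.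

The compounds shown leave open whether a different group at these places, such as bromo or a nitrile, would move the number beyond the scatter. They also leave open whether chloro on another aromatic carbon of either core would behave in the same way.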